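A Chloro Group on the Distal Phenyl of Compound 1

The compounds below may be only part of what the source reports. "The series", "measured", "known", "first", "only" and "open" are said of these compounds alone.

Compound 1 `COc1ccc(NCCNC(=O)[C@H](CC2CCCCC2)NC(=O)c2ccc(-c3ccccc3)cc2)cc1` was measured in an assay on isolated protein for inhibition of cathepsin S (Homo sapiens), at 37 degrees C, at pH 5.5 (a lower number here means a stronger inhibitor, a higher number a weaker inhibitor), where compound 1 gives 9.1 nM. It carries the highest of the two numbers recorded so far, yet its nearest neighbour, compound 2 `COc1ccc(NCCNC(=O)[C@H](CC2CCCCC2)NC(=O)c2cccc(Oc3ccccc3)c2)cc1`, gives 8 nM in this assay, and that difference lies within the scatter, so the two cannot be separated on these numbers. Within the data shown here, the two compounds differ in more than one place and no step between them is counted; only their two values are known.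

Compound 3 `COc1ccc(NCCNC(=O)[C@H](CC2CCCCC2)NC(=O)c2ccc(-c3cccc(Cl)c3)cc2)cc1` is the compound still to be measured. It differs from compound 1 in one place: chloro in place of hydrogen on an aromatic carbon. The rest of the shared core is kept unchanged.

Nothing measured here bears directly on this change. Because compound 1 already gives 9.1 nM and compound 2 gives 8 nM, the series sits in a narrow band, and the expected step of a 1.3-fold lower number from compound 1 to compound 3 (0.11 log units; within the scatter) for a single chloro in place of hydrogen is small, with no direction expected to exceed the scatter. Compound 3 is therefore expected to give about 7 nM in this assay, within a range from 3 nM to 18 nM.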

Compound 3, inhibition constant: 7.4 nM
Compound 3: middle estimate off by 1.1-fold (0.02 log units), on the low side, within the range that was stated.
By their numbers in this assay, from the lowest: compounds 3, 2 and 1 (each within the scatter of the next).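

Phenyl to 3-chlorophenyl is the only one-place step shown, and in this assay chloro in place of hydrogen amounts to a 1.2-fold lower number from compound 1 to compound 3 (0.09 log units; within the scatter), a step that cannot be told apart from repeat measurement. This aromatic carbon, meta to a large group, therefore accepts a chloro with no change that these numbers can resolve, so the hydrogen of compound 1 can give way to this single heavy atom without a measurable cost or gain in this read-out. Nothing available explains why the step is this small.

The compounds shown leave open whether a different group on this same carbon, such as an amine, a carboxylic acid or a methoxy group, would move the number beyond the scatter. They also leave open whether a chloro on another carbon of the same ring would behave as this one does, and whether the same change would give a similar step on the core of compound 2.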